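Amino on the core of compound 1: expected effect

The source may hold more compounds than are shown below. What is called first, only, known or untested is meant among the compounds shown, and "the series" means these compounds.

Two compounds of this series have numbers. In a functional assay on MCF7 cells (Homo sapiens) for inhibition, read by MTT assay, with a stated time of 48 h (on this read-out higher numbers stand for weaker inhibition and lower numbers for stronger inhibition), compound 1 `COc1cc2ccc(=O)oc2cc1OCCOc1no[n+]([O-])c1S(=O)(=O)c1ccccc1` gives 3540 nM. Compound 2 `COc1cc2ccc(=O)oc2cc1OCCCCOc1no[n+]([O-])c1S(=O)(=O)c1ccccc1` differs in the length of the chain linking the two parts of the molecule; in this assay compound 2 gives 3040 nM. Compound 1 stands at the higher of the two numbers, with compound 2 within the scatter of it, so the two values show no difference that can be read as an order.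

Compound 3 `COc1cc2cc(N)c(=O)oc2cc1OCCOc1no[n+]([O-])c1S(=O)(=O)c1ccccc1` is not yet measured. Relative to compound 1 the change is amino in place of hydrogen on an aromatic carbon, an amino in place of hydrogen on an aromatic carbon of the shared core. Going by the values given here, no measured pair shows this kind of change, so no step can be taken from the data; the chain change between compound 1 and compound 2 gives no guidance on a substituent on the core.

Absent a precedent, the expected step from compound 1 to compound 3 in this assay is a 1.2-fold lower number from compound 1 to compound 3 (0.07 log units; within the scatter), that is none beyond the scatter, with a wide allowance either way. Compound 3 is accordingly estimated at 3000 nM, within the range 1000 nM to 9000 nM.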

Compound 3, half-maximal inhibitory concentration: 2770 nM
Compound 3: the middle estimate sits 1.1-fold (0.03 log units) above what was measured; the measured number falls inside the stated range.
By their numbers in this assay, from the lowest: compounds 3, 2 and 1 (each within the scatter of the next).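

In this assay, amino in place of hydrogen on an aromatic carbon of the shared core gives a 1.3-fold lower number from compound 1 to compound 3 (0.11 log units; within the scatter), so at this position, two atoms from the ring oxygen, the change has no effect that can be told from the scatter. Going by these compounds alone, compound 1 and compound 2 differ only in the chain, so they said nothing about the core; this step gives the series its only reading there and shows that, with the chain of compound 1, the amino group is tolerated at this position in this cell assay without a readable gain or loss. No measurement is at hand that bears on this result.

Still open, on these data alone, is whether a larger or differently built group at this position, such as an acetamide, a nitro group or a carboxylic acid, would move the number beyond the scatter, given that one small group says little about the position as a whole. Also open, as far as these compounds go, is whether amino at this position gives a similar step on the longer chain of compound 2.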